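The compounds below may be only part of what the source reports. "The series", "measured", "known", "first", "only" and "open" are said of these compounds alone.

Compound 1 `COC(=O)[C@@]1(C)CC[C@@H]2C3=C1CC[C@@H](C)[C@]3(C)C[C@@H]1c3ccccc3N[C@H]21` and compound 2 `COC(=O)[C@@]1(C)CC[C@@H]2C3=C1CC[C@@H](C)[C@]3(C)Cc1c2[nH]c2ccccc12` share much of their skeleton, but the difference between the two cores is not broken down here. In a functional assay on HeLa cells (Homo sapiens) for inhibition, read by sulforhodamine B assay, with a stated time of 48 h (a lower number here means a stronger inhibitor of growth, a higher number a weaker inhibitor of growth), compound 1 gives 19000 nM, whereas compound 2 gives 3200 nM. Compound 3 `COC(=O)[C@@]1(C)CC[C@@H]2C3=C1CC[C@@H](C)[C@]3(C)Cc1c2[nH]c2ccc(C)cc12` carries one addition relative to compound 2, (methyl in place of hydrogen on an aromatic carbon), and in this assay compound 3 gives 11000 nM, which is a 3.4-fold higher number from compound 2 to compound 3 (0.54 log units; beyond the scatter). Compound 4 `COC(=O)[C@@]1(C)CC[C@@H]2C3=C1CC[C@@H](C)[C@]3(C)C[C@@H]1c3cccc(C)c3N[C@H]21` bears the same kind of change on compound 1, (methyl in place of hydrogen on an aromatic carbon), though the place is not the same: in compound 4 the methyl sits ortho to a fused ring and meta to a fused ring, while in compound 3 it sits meta to a fused ring and para to a fused ring. For the measured compounds named here, because a 3.4-fold higher number from compound 2 to compound 3 (0.54 log units; beyond the scatter) is the only precedent, compound 4 is expected to show a step of about a 2.4-fold higher number from compound 1 to compound 4 (0.37 log units; beyond the scatter), the different place and core leaving the size uncertain. In this assay compound 4 is thus estimated at 45000 nM, plausibly between 15000 nM and 130000 nM.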

Compound 4, concentration for 50% growth inhibition: 22000 nM
Compound 4: the middle estimate sits 2.0-fold (0.31 log units) above what was measured; measured number inside the range.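

Placing the methyl on the aromatic carbon ortho to a fused ring and meta to a fused ring gives a 1.2-fold higher number from compound 1 to compound 4 (0.06 log units; within the scatter) in this assay, so the size of the earlier step does not carry over to this core. The two steps differ: the same change on two cores in this assay, a 3.4-fold higher number (0.54 log units; beyond the scatter) from compound 2 to compound 3 and a 1.2-fold higher number (0.06 log units; within the scatter) from compound 1 to compound 4, 3.0-fold (0.47 log units) apart, beyond the scatter of two such steps. This shows that one methyl step cannot be taken as a guide to the other here, but it does not show whether the core or the place of the methyl accounts for the gap, as both differ between the two pairs.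

The compounds shown leave open whether a methyl at one matching place on both cores would give matching steps. They also leave open how a longer chain such as ethyl, a methoxy group or an amine on the same aromatic ring would read in this assay.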